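This account rests on a few compounds, and the source may have more. Where it says the series, first, only, none or still open, it means among the compounds named here.

Measured so far:
- compound 1 `CN1C(=S)N(C2CCCCC2)C(=O)/C1=C/c1ccc(O)cc1O`: 26000 nM
- compound 2 `CN1C(=S)N(C2CCCCC2)C(=O)/C1=C/c1ccc(N(C)C)cc1`: 12300 nM

Both values come from an assay for inhibition of NADPH oxidase 1 (Homo sapiens), read by chemiluminescence; on this read-out higher numbers stand for weaker inhibition and lower numbers for stronger inhibition. Compound 1 gives the higher of the two numbers; compound 2 sits lower, and the gap between them lies beyond the usual scatter. The two compounds differ in more than one place, so no single step can be read from them.

Compound 3 `CCc1ccc(N2C(=O)/C(=C/c3ccc(O)cc3O)N(C)C2=S)cc1` has not been measured in this assay. It differs from compound 1 in one place: 4-ethylphenyl in place of cyclohexyl on an amide-type nitrogen in a ring. Nothing in the measured pair speaks to this exchange, so no direction is backed by data. A small step is expected from compound 1 to compound 3, leaning toward a somewhat lower number but possibly within the scatter, estimated as a 1.4-fold lower number from compound 1 to compound 3 (0.16 log units; within the scatter). Compound 3 is accordingly expected to give about 18000 nM, within a range of 6000 nM to 55000 nM.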

Compound 3, inhibition constant: 8400 nM
The estimate for compound 3 lay 2.1-fold (0.33 log units) above the measured number; the measured number falls inside the stated range.
By their numbers in this assay, from the lowest: compounds 3 and 2 (each within the scatter of the next); then compound 1.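

In this assay, 4-ethylphenyl in place of cyclohexyl on an amide-type nitrogen in a ring gives a 3.1-fold lower number from compound 1 to compound 3 (0.49 log units; beyond the scatter) and so a modest step beyond the scatter. For the compounds shown here, this is the first reading of a single change: this position accepts an aromatic ring carrying an ethyl group with no loss, and the number falls while the rest of compound 1 stays unchanged. Nothing at hand bears on what lies behind this step.

The compounds shown do not separate the aromatic ring from its ethyl group, a question that plain phenyl or a butyl chain at this nitrogen would address. Also open, from the compounds shown here alone, is whether the same exchange gives a like step on compound 2, which keeps cyclohexyl at this place.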